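This account rests on a few compounds, and the source may have more. Where it says the series, first, only, none or still open, it means among the compounds named here.

Measured compounds:
Compound 1 `CC1CCN(c2ccc(Nc3ncc4c(n3)N(C3CCCC3)CC(=O)N4)cc2)CC1`; in a functional assay on MDA-MB-231 cells (Homo sapiens) for inhibition, read by MTT assay, with a stated time of 48 h (on this read-out lower numbers stand for stronger inhibition and higher numbers for weaker inhibition), compound 1 gives 22700 nM.
Compound 2 `CN1CCN(c2ccc(Nc3ncc4c(n3)N(C3CCCC3)CC(=O)N4)nc2)CC1`; compound 2 gives only a limit of this assay, > 30000 nM.
Compound 3 `O=C1CN(C2CCCC2)c2nc(Nc3ccc(N4CCCCC4)cn3)ncc2N1`; compound 3 likewise gives only a limit, > 30000 nM.

Compound 3 therefore stands at the limit, where (the limit of > 30000 nM in this assay, at which 2 of the 3 values shown sit); its value is not a number. Among the compounds with values here, the only single-point step among the measured compounds, a step that the two limits leave unreadable from compound 2 to compound 3, runs between two limits and its size cannot be read. Compound 4 `CC1CCN(c2ccc(Nc3ncc4c(n3)N(C3CCCC3)CC(=O)N4)nc2)CC1` differs from compound 3 by methyl in place of hydrogen on a saturated ring carbon. Within the data shown here, no measured step bears directly on this change. Among the measured compounds shown here, compound 1 also carries the 4-methylpiperidin-1-yl group and is the one compound with a number, but it differs from compound 4 in a further place, so its value shows only that such a compound can fall inside the readable range. Compound 4 is expected to remain near the limit, with the step that the limit leaves unreadable from compound 3 to compound 4 estimated as none beyond the scatter. The estimate for compound 4 in this assay is 35000 nM, between 15000 nM and 80000 nM.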

Compound 4, half-maximal inhibitory concentration: > 30000 nM
Compound 4 ended at the assay's limit; the forecaster's own chance of this, stated with the estimate: 65%; the middle value lies beyond the limit too.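

Within the data shown here, compound 2, compound 3 and compound 4 all give only a limit in this assay, so no step among them can be read. Going by these compounds, what remains open is whether piperidin-1-yl to 4-methylpiperidin-1-yl changes inhibition at all.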